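The compounds below may be only part of what the source reports. "The series", "measured", "known", "first", "only" and "open" are said of these compounds alone.

In a functional assay on MCF7 cells (Homo sapiens) for antiproliferative activity, read by CellTiter-Glo, with a stated time of 5 days (a lower number here means a stronger inhibitor, a higher number a weaker inhibitor), compound 1, `CC/C(=C(/c1ccc(/C=C/C(=O)O)cc1)c1ccc2nnnn2c1)c1ccccc1`, gives > 500 nM, which is a limit of the assay and not a number. Compound 2, `CC/C(=C(/c1ccc(/C=C/C(=O)O)cc1)c1ccc2ocnc2c1)c1ccccc1`, gives > 500 nM, also only a limit, so its position on the scale is open. Both compounds thus stand at the limit of > 500 nM in this assay, at which 2 of the 2 values shown sit. Compound 3, `CC/C(=C(/c1ccc(/C=C/C(=O)O)cc1)c1ccc2ccccc2c1)c1ccccc1`, has naphthalen-2-yl in place of 1,3-benzoxazol-5-yl on a double-bonded chain carbon bound to an aromatic carbon and a double-bonded chain carbon. Among the compounds with values here, the one measured step that bears on this change, at the same carbon, is a step that the two limits leave unreadable from compound 1 to compound 2, so it offers no size to carry forward. The expectation therefore rests on little. Compound 3 is the only one of the three whose group here has rings of carbon only, while compound 1 and compound 2 both sit at the limit of > 500 nM in this assay, at which 2 of the 2 values shown sit. A shift toward a stronger inhibitor is expected in this assay, though with low confidence. The expected change is an at least 3.3-fold lower number from compound 2 to compound 3 (0.52 log units; beyond the scatter). Compound 3 is estimated at 150 nM, with an expected range of 20 nM to 900 nM.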

Compound 3, half-maximal inhibitory concentration: 180 nM
Beside the measured number, compound 3's estimate is 1.2-fold (0.08 log units) below it, within the range that was stated.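

In this assay, within the data shown here, naphthalen-2-yl is the first group at this double-bonded chain carbon to give a number rather than a limit, and putting it in place of 1,3-benzoxazol-5-yl gives an at least 2.7-fold lower number from compound 2 to compound 3 (0.44 log units; beyond the scatter). The same group, set against the group of compound 1, gives an at least 2.7-fold lower number from compound 1 to compound 3 (0.44 log units; beyond the scatter), and in both steps the printed size is only a minimum, as one end of each is a limit of the assay. Among these compounds, this shows that the position tolerates a change that moves the number beyond the scatter, with rings of carbon only as the one feature that sets compound 3 apart from the other two, while the step between compound 1 and compound 2 cannot be read and the two stay at a limit, not a number: the limit of > 500 nM in this assay, at which 2 of the 3 values shown sit.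

The compounds shown leave open whether the gain follows from losing the ring nitrogen and oxygen or from the change in ring shape, and a quinolin-6-yl or indol-5-yl group at the same carbon would help separate the two. They also leave open how far the number of compound 1 and compound 2 lies from that of compound 3, and whether a plain phenyl group would keep any of the gain.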